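Taking the methyl group off compound 2

The source may hold more compounds than are shown below. What is called first, only, known or untested is meant among the compounds shown, and "the series" means these compounds.

Compound 1 `C=C1CC(COc2ccc3cccc(O)c3n2)(c2ccccc2)OC1=O`: 1290 nM
Compound 2 `C=C1CC(COc2cccc3ccc(C)nc23)(c2ccccc2)OC1=O`: 1450 nM

In a functional assay on LOX IMVI cells (Homo sapiens) for antiproliferative activity (a higher number here means a weaker inhibitor of growth, a lower number a stronger inhibitor of growth), compound 2 stands within the scatter of compound 1, so the two numbers cannot be told apart. Compound 3 `C=C1CC(COc2cccc3cccnc23)(c2ccccc2)OC1=O` has not yet been measured. It differs from compound 2 in one place, with hydrogen in place of methyl on an aromatic carbon and the rest unchanged. Among the compounds with values here, no measured pair shows what this exchange does on its own. Within the data shown here, the only guide is that compound 1 at 1290 nM and compound 2 at 1450 nM lie close together although they carry different substituents. No step beyond the scatter is expected, and no direction is favoured: the estimated 1.1-fold higher number from compound 2 to compound 3 (0.04 log units; within the scatter) is small. Compound 3 is expected at 1600 nM with an estimated range of 650 nM to 3800 nM overall.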

Compound 3, concentration for 50% growth inhibition: 1350 nM
Beside the measured number, compound 3's estimate is 1.2-fold (0.07 log units) above it; low and high end bracket the measured number.
By their numbers in this assay, from the lowest: compounds 1, 3 and 2 (each within the scatter of the next).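

In this assay, within the data shown here, hydrogen in place of methyl on this aromatic carbon, next to the ring nitrogen, gives a 1.1-fold lower number from compound 2 to compound 3 (0.03 log units; within the scatter), and this is the first direct reading of the exchange on its own. At this position the methyl group can therefore be removed with no step beyond the scatter, so compound 2 and compound 3 cannot be told apart. No independent measurement offers an explanation for this result.

The compounds shown carry only methyl and hydrogen at this carbon, so it remains open whether a longer chain such as propyl, an amine or a carboxylic acid would also stay within the scatter. As far as these compounds go, it is also open whether the same exchange would read alike in another cell line or on a core with other substituents.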